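Amide substituent variation on the fluorinated exocyclic enamide series

The source may hold more compounds than are shown below. What is called first, only, known or untested is meant among the compounds shown, and "the series" means these compounds.

Compound 3 `CCN(C)C(=O)/C=C1\CCc2ccc(F)cc21` gives 20% in a functional assay on the whole organism with Rattus norvegicus as the target, at a dose of 20 mg/kg by the oral route (a higher number here means more inhibition at the dose given (going by the name of the read-out), a lower number less inhibition), the second highest of the three numbers measured. Compound 2 `CC(C)NC(=O)/C=C1\CCc2ccc(F)cc21` gives 45%, and compound 1 `O=C(/C=C1\CCc2ccc(F)cc21)NCC1CC1` gives 0%. Compound 4 `CCCNC(=O)/C=C1\CCc2ccc(F)cc21` carries the change (propylamino in place of ethyl(methyl)amino on a carbonyl carbon). Going by the values given here, the steps that bear on it are a number 25 percentage points lower from compound 2 to compound 3 (beyond the scatter) and a number 20 percentage points higher from compound 1 to compound 3 (beyond the scatter): both secondary amides measured so far bracket compound 3, one higher and one lower, so the return to a secondary amide in compound 4 is expected to give at most a modest step upward, a number 10 percentage points higher from compound 3 to compound 4 (within the scatter), with wide uncertainty because a number 45 percentage points higher from compound 1 to compound 2 (beyond the scatter) shows that the two secondary amides differ greatly from each other. Compound 4 is therefore estimated at 30%, between 5% and 55%.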

Compound 4, a percentage reported as inhibition, in the whole organism at one dose (the size of the read-out at that dose, not a potency): 0%
Beside the measured number, compound 4's estimate is 30 percentage points above it, and the stated range ends above it.
By their numbers in this assay, from the lowest: compounds 1 and 4 (each within the scatter of the next); then compound 3; then compound 2.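

In this assay, the amide hydrogen alone does not raise the number: a number 20 percentage points lower from compound 3 to compound 4 (beyond the scatter), leaving the ethyl(methyl)amino amide above this propylamino amide. Among the secondary amides only isopropyl stands apart, with a number 45 percentage points lower from compound 2 to compound 4 (beyond the scatter), whereas no change at the digits printed from compound 1 to compound 4 (within the scatter) for ethyl in place of cyclopropyl on the chain carbon. No available evidence bears on these steps. As far as these compounds go, whether a tert-butyl or cyclobutyl group on the amide nitrogen matches the number of compound 2 remains open. So does whether a longer chain ending in a hydroxyl or an amine gives any inhibition.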